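Inverting the lone stereocentre of compound 3

The source may hold more compounds than are shown below. What is called first, only, known or untested is meant among the compounds shown, and "the series" means these compounds.

In an ADME assay on the whole organism for inhibition, with Echinochloa crus-galli var. formosensis as the target, with a stated time of 4 days (on this read-out higher numbers stand for weaker inhibition and lower numbers for stronger inhibition), compound 1 (`CCCNc1nc(Cl)nc(N[C@H](C)c2ccccc2)n1`) reads 33100 nM and compound 2 (`CNc1nc(Cl)nc(N[C@H](C)c2ccccc2)n1`) reads 562 nM while compound 3 (`CCCN(C)c1nc(Cl)nc(N[C@H](C)c2ccccc2)n1`) reads 9770 nM and so sits in the middle of the three. Its neighbours are set by two steps, a 3.4-fold lower number from compound 1 to compound 3 (0.53 log units; beyond the scatter) and a 17-fold higher number from compound 2 to compound 3 (1.24 log units; beyond the scatter), both beyond the scatter. Against compound 3, compound 4 (`CCCN(C)c1nc(Cl)nc(N[C@@H](C)c2ccccc2)n1`) shows a single difference (the two compounds have the same atoms and bonds and differ only in configuration as drawn: 1 of 1 stereo elements differ; a stereocentre at a saturated chain carbon is drawn R in compound 3 and S in compound 4), so the stereocentre at a saturated chain carbon goes from R as drawn to S as drawn.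

Within the data shown here, no measured step touches that stereocentre, since all three measured compounds are drawn with the same configuration there. The data therefore give no direct size or direction for this change. They bear on it only indirectly: changes elsewhere in the structure moved the number considerably, as in a 59-fold lower number from compound 1 to compound 2 (1.77 log units; beyond the scatter), which shows how far this read-out can travel within the set. A step beyond the scatter towards a higher number is expected, though this direction is a judgement and the range stays wide. The estimated step is a 5.1-fold higher number from compound 3 to compound 4 (0.71 log units; beyond the scatter) and remains an expectation. For compound 4 the expected value is 50000 nM (estimated range 10000 nM to 250000 nM) on this read-out.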

Compound 4, half-maximal inhibitory concentration: 380 nM
The estimate for compound 4 lay 130-fold (2.12 log units) above the measured number; the measured number lies below the stated range.
By their numbers in this assay, from the lowest: compounds 4 and 2 (each within the scatter of the next); then compound 3; then compound 1.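

The stereocentre at the saturated chain carbon proved to be a strong control on this assay, not a silent feature of the series: a 26-fold lower number from compound 3 to compound 4 (1.41 log units; beyond the scatter). The earlier steps shown here all came from changes on the nitrogen substituents, and this inversion moves the number on a scale comparable with one of them, a 17-fold higher number from compound 2 to compound 3 (1.24 log units; beyond the scatter), while every atom and bond stays the same. The whole of the new step belongs to the configuration at this one carbon because nothing else separates the pair: the fact that compounds 3 and 4 differ only in the configuration as drawn

From the compounds shown here alone, compound 1 and compound 2 are drawn only with the R configuration, so it remains open whether S as drawn would also give a lower number with their substituents on the nitrogen, or whether the size of the effect depends on the N-methyl-N-propyl pattern of compound 3 and compound 4. Also open, going by these compounds, is whether the gap between the two configurations survives when an ethyl group or a longer chain replaces the methyl group on the stereocentre, or when a cyclopropyl group replaces the propyl chain.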